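Ethylsulfonyl in Place of Ethylcarbamoyl: Expected Permeability

The compounds below may be only part of what the source reports. "The series", "measured", "known", "first", "only" and "open" are said of these compounds alone.

Measured so far:
Compound 1 `CCCC(=O)N1CCC(CN(C2Cc3cc(C#N)ccc3N(Cc3cncn3C)C2)S(=O)(=O)c2ccccn2)CC1` gives 0.5 10^-6 cm/s in an ADME assay on Caco-2 cells (Homo sapiens) for permeability, in the apical to basolateral direction; on this read-out higher numbers stand for higher permeability and lower numbers for lower permeability.
Compound 2 `Cc1noc(C)c1CN(C1Cc2cc(C#N)ccc2N(Cc2cncn2C)C1)S(=O)(=O)c1ccccn1` gives 8 10^-6 cm/s in this assay.
Compound 3 `CCNC(=O)N1CCC(CN(C2Cc3cc(C#N)ccc3N(Cc3cncn3C)C2)S(=O)(=O)c2ccccn2)CC1` gives 0.6 10^-6 cm/s in this assay.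

Compound 3 stands second highest of the three numbers, close to compound 1 and far below compound 2, as seen in a 13-fold lower number from compound 2 to compound 3 (1.12 log units; beyond the scatter). Compound 4 `CCS(=O)(=O)N1CCC(CN(C2Cc3cc(C#N)ccc3N(Cc3cncn3C)C2)S(=O)(=O)c2ccccn2)CC1` differs from compound 3 by ethylsulfonyl in place of ethylcarbamoyl on an amine nitrogen in a ring. The step most like this one changes only the group on the same ring nitrogen: a 1.2-fold higher number from compound 1 to compound 3 (0.08 log units; within the scatter), which is within the scatter. The large steps of a 16-fold higher number from compound 1 to compound 2 (1.20 log units; beyond the scatter) and a 13-fold lower number from compound 2 to compound 3 (1.12 log units; beyond the scatter) exchange the whole piperidine unit and therefore do not speak to a change kept on that nitrogen. For compound 4 no step beyond the scatter is expected in this assay, that is a 1.2-fold higher number from compound 3 to compound 4 (0.07 log units; within the scatter). The estimate for compound 4 is 0.7 10^-6 cm/s, expected to fall between 0.3 10^-6 cm/s and 1.6 10^-6 cm/s.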

Compound 4, apparent permeability: 0.1 10^-6 cm/s
For compound 4 the middle estimate is 7.0-fold (0.85 log units) above the measured one; measured number below the stated range.
By their numbers in this assay, from the lowest: compound 4; then compounds 1 and 3 (each within the scatter of the next); then compound 2.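

In this assay, the group on the ring nitrogen does matter: ethylsulfonyl in place of ethylcarbamoyl gives a clear drop (a 6.0-fold lower number from compound 3 to compound 4 (0.78 log units; beyond the scatter)), and ethylsulfonyl in place of propylcarbonyl gives a similar one (a 5.0-fold lower number from compound 1 to compound 4 (0.70 log units; beyond the scatter)). Among these compounds, the two carbonyl groups had stayed within the scatter of each other, so this is the first change on that nitrogen to move the number. Set against the 3,5-dimethyl-1,2-oxazol-4-yl group, 1-(ethylsulfonyl)piperidin-4-yl gives the widest gap so far (an 80-fold lower number from compound 2 to compound 4 (1.90 log units; beyond the scatter)).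

Nothing measured here explains the drop. Going by these compounds, whether methylsulfonyl or phenylsulfonyl on this nitrogen would read like ethylsulfonyl stays open.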